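Removing One Chloro from a Dichloropurine Benzyl Series

This account rests on a few compounds, and the source may have more. Where it says the series, first, only, none or still open, it means among the compounds named here.

Of the compounds shown here, two have been measured in a functional assay on UACC-62 cells (Homo sapiens) for cytotoxicity, read by sulforhodamine B assay, with a stated time of 48 h; on this read-out lower numbers stand for stronger inhibition of growth and higher numbers for weaker inhibition of growth. Compound 1 `ClCc1ccccc1Cn1cnc2c(Cl)nc(Cl)nc21` gives 1310 nM in this assay. Compound 2 `ClCc1ccc(Cn2cnc3nc(Cl)nc(Cl)c32)cc1` gives 1650 nM in this assay, a number that sits within the scatter of the value of compound 1, so neither can be called stronger. Compound 3 `ClCc1ccc(Cn2cnc3ncnc(Cl)c32)cc1` differs from compound 2 by hydrogen in place of chloro on an aromatic carbon, a hydrogen in place of chloro on an aromatic carbon. Within the data shown here, no such step has been measured here, so the direction is open; a modest weakening is expected. For compound 3 the expected value in this assay is 2500 nM, with a range of 900 nM to 7000 nM, meaning an expected step of a 1.5-fold higher number from compound 2 to compound 3 (0.18 log units; within the scatter).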

Compound 3, concentration for 50% growth inhibition: 2510 nM
Compound 3: the middle estimate sits 1.0-fold (0.00 log units) below what was measured; low and high end bracket the measured number.
By their numbers in this assay, from the lowest: compounds 1, 2 and 3 (each within the scatter of the next).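

In this assay, replacing this chloro with hydrogen gives a 1.5-fold higher number from compound 2 to compound 3 (0.18 log units; within the scatter) and so provides the first single-place comparison among these compounds. At the aromatic carbon between two ring nitrogen atoms, the chloro is therefore not shown to be needed for growth inhibition, since the loss of this one heavy atom leaves compound 3 within the scatter of compound 2. Nothing available explains this result. 

As far as these compounds go, whether an amine or a methoxy group at this carbon would shift the number beyond the scatter remains open. So does the outcome of replacing the remaining chloro or the chloromethyl group with hydrogen.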